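The source may hold more compounds than are shown below. What is called first, only, known or untested is meant among the compounds shown, and "the series" means these compounds.

Three compounds share the core of compound 1 `CC(C#Cc1cccc(C(=O)NCCC(c2ccccc2)c2ccc(OC(F)(F)F)cc2)c1)N(O)C(N)=O`, alongside compound 2 `C[C@H](C#Cc1cccc(C(=O)NCCC(c2ccc(F)cc2)c2ccc(C(F)(F)F)cc2)c1)N(O)C(N)=O` and compound 3 `CC(C)CC(C#Cc1cccc(C(=O)NCc2ccccc2C(F)(F)F)c1)N(O)C(N)=O`. In an assay for inhibition of Polyunsaturated fatty acid 5-lipoxygenase (Homo sapiens), read by HPLC, with stated times of 15 min and 10 min (a higher number here means a weaker inhibitor, a lower number a stronger inhibitor), compound 1 gives 110 nM. Compound 2 gives 220 nM in this assay. Compound 3 gives 600 nM in this assay, the highest of the three numbers, with its gap to compound 2 and its wider gap to compound 1 both beyond the scatter. Compound 4 `CCCC(C#Cc1cccc(C(=O)NCc2ccccc2C(F)(F)F)c1)N(O)C(N)=O` differs from compound 3 by hydrogen in place of methyl on a saturated chain carbon bound to two saturated chain carbons. Going by the values given here, no pair among the measured compounds isolates such a change, so the direction rests on expectation alone. The step from compound 3 to compound 4 is expected to be small, a 1.2-fold higher number from compound 3 to compound 4 (0.07 log units; within the scatter), not clearly beyond the scatter. Compound 4 is therefore estimated at 700 nM, between 300 nM and 1600 nM.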

Compound 4, half-maximal inhibitory concentration: 300 nM
Estimate against measurement, compound 4: 2.3-fold (0.37 log units) above, and the stated range covers the measured number.
By their numbers in this assay, from the lowest: compounds 1, 2, 4 and 3 (each within the scatter of the next, the first and the last beyond it).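

Going by these compounds alone, the first pair here that differs in one place gives, in this assay, a 2.0-fold lower number from compound 3 to compound 4 (0.30 log units; within the scatter). Isobutyl to propyl at this position, a saturated chain carbon bound to two saturated chain carbons, therefore leaves the number within the scatter, so this methyl is not shown to matter in this series. Nothing measured here bears on the reason for this result.

As far as these compounds go, whether a longer chain, a cyclopropyl group or an amine at this position would move the number beyond the scatter remains open. So does whether the same change would read alike with the amide side chain of compound 1.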